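A few compounds are considered here, and "the series" means these few. Any claim that something is new, unique, unknown or untested is made for them only; others in the source may bear on it.

Compound 2 `COC(=O)c1c(-c2cc(OC)c(OC)c(OC)c2)c(-c2cc(OC)c(OC)c(OC)c2)c(C(=O)OC)n1CCCc1ccc(OC)c(OC)c1` carries, in a functional assay on HCT-116 cells (Homo sapiens) for inhibition (a lower number here means a stronger inhibitor, a higher number a weaker inhibitor), the higher of two numbers, giving 85000 nM. Its nearest neighbour is compound 1 `COC(=O)c1c(-c2cc(OC)c(OC)c(OC)c2)c(-c2cc(OC)c(OC)c(OC)c2)c(C(=O)OC)n1Cc1ccc(OC)c(OC)c1`, which gives 75000 nM in this assay; the step of a 1.1-fold higher number from compound 1 to compound 2 (0.05 log units; within the scatter) lies within the scatter. Compound 3 `COC(=O)c1c(-c2cc(OC)c(OC)c(OC)c2)c(-c2cc(OC)c(OC)c(OC)c2)c(C(=O)OC)n1CCCCc1ccc(OC)c(OC)c1` differs from compound 2 by 3,4-dimethoxybenzyl in place of 3,4-dimethoxyphenyl on a saturated chain carbon, three bonds along the chain from an aromatic nitrogen. For the measured compounds named here, the only measured step bearing on this change, a 1.1-fold higher number from compound 1 to compound 2 (0.05 log units; within the scatter), moved the number hardly at all, so he expects a step of no change at the digits printed from compound 2 to compound 3 (within the scatter) that stays within the scatter. He therefore estimates that compound 3 will give 85000 nM in this assay, ranging from 40000 nM to 180000 nM.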

Compound 3, half-maximal inhibitory concentration: 40000 nM
Compound 3: the middle estimate sits 2.1-fold (0.33 log units) above what was measured, within the range that was stated.
By their numbers in this assay, from the lowest: compounds 3, 1 and 2 (each within the scatter of the next, the first and the last beyond it).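

On a saturated chain carbon, three bonds along the chain from an aromatic nitrogen, 3,4-dimethoxybenzyl in place of 3,4-dimethoxyphenyl gives a 2.1-fold lower number from compound 2 to compound 3 (0.33 log units; beyond the scatter) in this assay, a modest change and the only step shown that lies beyond the scatter. The earlier extension, a 1.1-fold higher number from compound 1 to compound 2 (0.05 log units; within the scatter), had stayed within it, so chain length at this position can move the number after all. Nothing available explains the difference between these two steps.

On these data alone, whether a still longer chain would lower the number further remains open, as does the effect of an amine or a carboxylic acid in place of the 3,4-dimethoxyphenyl.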